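Removing the trifluoromethyl from compound 1

This account rests on a few compounds, and the source may have more. Where it says the series, first, only, none or still open, it means among the compounds named here.

Compound 1 `C/C(=N\NC(=O)c1ccc(C(F)(F)F)cc1)c1cnccn1`: 2
Compound 2 `C/C(=N\NC(=O)c1cccs1)c1cnccn1`: 2.6
Compound 3 `C/C(=N\NC(=O)c1cccc(Br)c1)c1cnccn1`: 2.9

Of the compounds shown here, three sharing one core have been measured in a physicochemical assay for lipophilicity; on this read-out higher numbers stand for higher lipophilicity and lower numbers for lower lipophilicity. Compound 1 stands lowest of the three; compound 2 gives 2.6, a number higher by more than the usual scatter, and compound 3 gives 2.9, further above it still.

Compound 4 `C/C(=N\NC(=O)c1ccccc1)c1cnccn1` has not yet been measured. It differs from compound 1 in one place: hydrogen in place of trifluoromethyl on an aromatic carbon. Among the compounds with values here, no pair of measured compounds shows the effect of this particular change, so the size of the step is uncertain. Taking compound 1 at 2 as the starting point, and noting that compound 3 carries a different single group on the same ring and gives 2.9, a modest downward step is expected, roughly a number 0.20 log units lower from compound 1 to compound 4 (within the scatter), though it may fall within the scatter. For compound 4 the estimate in this assay is 1.8, with a range from 1 to 2.6.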

Compound 4, partition coefficient: 1.9
The estimate for compound 4 lay 0.10 log units below the measured number, and the stated range covers the measured number.
By their numbers in this assay, from the lowest: compounds 4 and 1 (each within the scatter of the next); then compounds 2 and 3 (each within the scatter of the next).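

In this assay, hydrogen in place of trifluoromethyl on this aromatic carbon gives a number 0.10 log units lower from compound 1 to compound 4 (within the scatter), so the two groups cannot be told apart at this position. Hydrogen in place of bromo on an aromatic carbon gives a clearer change, a number 1.00 log units lower from compound 3 to compound 4 (beyond the scatter), which shows that a single group on this ring can matter in this read-out even though trifluoromethyl does not. Phenyl in place of thiophen-2-yl on a carbonyl carbon gives a number 0.70 log units lower from compound 2 to compound 4 (beyond the scatter), the first step here that exchanges the ring itself.

Nothing available explains why removing trifluoromethyl and removing bromo differ so much. As far as these compounds go, it remains open whether an amine or a carboxylic acid on this aromatic carbon would stay within the scatter of compound 4 or move the number beyond it.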